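Adding a Chlorine to the Thioester Coumarin

The source may report more compounds than this note shows. Statements on the series, on what has been measured and on what is new or still open speak of the compounds shown alone.

Compound 1 `CC(=O)OCc1ccc2oc(=O)c(C(=O)Oc3cccc(Br)c3)cc2c1`: 11.8%
Compound 2 `CC(=O)OCc1ccc2oc(=O)c(C(=O)Sc3ccccc3)cc2c1`: 73.8%

Both compounds were tested in a functional assay on HT-1080 cells (Homo sapiens), read by transwell migration, with a stated time of 24 h, tested at 10 uM; a higher number here means a weaker effect of the compound at the concentration tested, a lower number a stronger effect. Compound 2 stands highest of the two numbers; its nearest neighbour is compound 1, separated by the step of a number 62 percentage points higher from compound 1 to compound 2 (beyond the scatter). That step exchanges the linking atom and the halogen at the same time, so it does not isolate either change on its own.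

Compound 3 `CC(=O)OCc1ccc2oc(=O)c(C(=O)Sc3cccc(Cl)c3)cc2c1` has not yet been measured. It differs from compound 2 in a single place: chloro in place of hydrogen on an aromatic carbon. Going by the values given here, no measured step adds a halogen alone to an otherwise unchanged compound, so the one available step is only a loose guide; it hints that a halogen on the outer ring goes with lower numbers, though the linking atom also differed there. A moderate decrease beyond the scatter is therefore expected, with wide uncertainty. The expected step is a number 18.8 percentage points lower from compound 2 to compound 3 (beyond the scatter). For compound 3 the estimate in this assay is 55%, within a range from 25% to 85%.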

Compound 3, a percentage reported as activity, at one concentration (the size of the read-out at that concentration, not a potency): 61.9%
Beside the measured number, compound 3's estimate is 6.9 percentage points below it, within the range that was stated.
By their numbers in this assay, from the lowest: compound 1; then compound 3; then compound 2.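

In this assay, going by these compounds alone, chloro in place of hydrogen on the outer ring, with the sulfur link held fixed, gives a number 11.9 percentage points lower from compound 2 to compound 3 (beyond the scatter) and so shows for the first time what a halogen at this ring carbon does on its own: it lowers the number modestly. A large distance to the oxygen-linked compound remains, seen in a number 50.1 percentage points higher from compound 1 to compound 3 (beyond the scatter) and still combining a change of linking atom with chlorine against bromine, so adding the chlorine closes only a small part of the gap. Nothing measured here gives a reason for either step.

Open, from the compounds shown here alone, is how the sulfur and oxygen links compare when both carry the same halogen. Also open, going by these compounds, is how bromo, methoxy or an amine at this ring carbon, or an amide nitrogen as the linking atom, would read.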